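Replacing the amide amine in a cathepsin S inhibitor series

The source may report more compounds than this note shows. Statements on the series, on what has been measured and on what is new or still open speak of the compounds shown alone.

Measured compounds:
- compound 1, `C[C@@H]1CN(C(=O)[C@@H]2C[C@H](S(=O)(=O)c3ccccc3)C[C@H]2C(=O)NC2(C#N)CC2)C[C@H](C)O1`: 0.4 nM
- compound 2, `CN1CCN(C(=O)[C@@H]2C[C@H](S(=O)(=O)c3ccccc3)C[C@H]2C(=O)NC2(C#N)CC2)CC1`: 2 nM

In an assay on isolated protein for inhibition of cathepsin S (Homo sapiens), read by fluorescence, with a stated time of 20 min (on this read-out lower numbers stand for stronger inhibition and higher numbers for weaker inhibition), compound 2 gives 2 nM, the higher of the two numbers recorded so far. Among the compounds with values here, its nearest neighbour is compound 1, and the only measured step, a 5.0-fold higher number from compound 1 to compound 2 (0.70 log units; beyond the scatter), shows what exchanging one amine on the carbonyl carbon for another can do. The unmeasured compound 3, `N#CC1(NC(=O)[C@@H]2C[C@@H](S(=O)(=O)c3ccccc3)C[C@H]2C(=O)Nc2ccc(F)cc2)CC1`, takes this further: (4-fluorophenyl)amino in place of 4-methylpiperazin-1-yl on a carbonyl carbon. Within the data shown here, no measured pair shows this particular exchange, so the one step above serves only as a rough guide to how much such changes move the number. A modest step is therefore expected, with the number more likely to rise than fall, though a result within the scatter would not surprise. Compound 3 is estimated at 6 nM, within a range of 1 nM to 30 nM, which corresponds to the expected step of a 3.0-fold higher number from compound 2 to compound 3 (0.48 log units; beyond the scatter).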

Compound 3, half-maximal inhibitory concentration: 26 nM
Compound 3: the middle estimate sits 4.3-fold (0.64 log units) below what was measured, and the stated range covers the measured number.
By their numbers in this assay, from the lowest: compound 1; then compound 2; then compound 3.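

Replacing a saturated ring amine on the carbonyl carbon with (4-fluorophenyl)amino moves the number much further in this assay than exchanging one saturated ring amine for another, which gave only a 5.0-fold higher number from compound 1 to compound 2 (0.70 log units; beyond the scatter) as a modest step. The new group gives a 13-fold higher number from compound 2 to compound 3 (1.11 log units; beyond the scatter) and, set against 2,6-dimethylmorpholin-4-yl, a 65-fold higher number from compound 1 to compound 3 (1.81 log units; beyond the scatter) as well, both large steps, so this position is far from indifferent to what sits on the carbonyl. No outside measurement accounts for the size of these steps.

Still open, on these data alone, is which feature of the new group matters: its aromatic ring, its fluorine or its amide hydrogen. Phenylamino without the fluorine, or an open-chain amine such as dimethylamino, on the same carbonyl carbon would help to separate these features.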